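The source may hold more compounds than are shown below. What is called first, only, known or untested is meant among the compounds shown, and "the series" means these compounds.

Of the compounds shown here, two on a shared core have been measured in a functional assay on NCI-H460 cells (Homo sapiens) for antiproliferative activity, read by MTT assay, with a stated time of 48 h (a higher number here means a weaker inhibitor, a lower number a stronger inhibitor), so far. Within the data shown here, compound 1 (`CCCCC1(O)C(=O)Nc2ccc(Nc3ccc(C)cc3)cc21`) gives 31800 nM in that test, and compound 2 (`CCCCC1(O)C(=O)Nc2ccc(Nc3ccc(F)cc3)cc21`) gives 32500 nM there, so compound 2 stands level with the only other number available. Among the measured compounds shown here, the one measured step, fluoro in place of methyl on an aromatic carbon, is a 1.0-fold higher number from compound 1 to compound 2 (0.01 log units; within the scatter) and does not separate them.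

Compound 3 (`O=C1Nc2ccc(Nc3ccc(F)cc3)cc2C1(O)Cc1ccccc1`) keeps the fluoro group of compound 2 and alters the chain instead: phenyl in place of propyl on a saturated chain carbon bound to a saturated ring carbon in words, phenyl in place of propyl on a saturated chain carbon bound to a saturated ring carbon, or butyl to benzyl when cut one bond further out. For the measured compounds named here, the measured step concerns a different place in the structure, and no measured pair varies this chain, so the data give no direct size for the change. Compound 2 at 32500 nM therefore remains the anchor, and no shift beyond the scatter is expected in this assay (the expected step is a 1.3-fold lower number from compound 2 to compound 3 (0.11 log units; within the scatter) with wide uncertainty in either direction). For compound 3 the estimated value is 25000 nM (expected range 9000 nM to 60000 nM).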

Compound 3, half-maximal inhibitory concentration: 18100 nM
The estimate for compound 3 lay 1.4-fold (0.14 log units) above the measured number; low and high end bracket the measured number.
By their numbers in this assay, from the lowest: compounds 3, 1 and 2 (each within the scatter of the next).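

Among these compounds, this is the first measured change at the chain rather than on the aromatic carbon carrying the fluoro group. In this assay, butyl to benzyl gives a 1.8-fold lower number from compound 2 to compound 3 (0.25 log units; within the scatter), so placing phenyl in place of propyl on a saturated chain carbon bound to a saturated ring carbon, with its six-membered aromatic ring and larger count of heavy atoms, does not separate compound 3 from compound 2. Like the earlier step of a 1.0-fold higher number from compound 1 to compound 2 (0.01 log units; within the scatter), this one stays within the scatter, and nothing available offers an explanation for the size of either step.

The compounds shown leave open whether any group at this chain position can move the number beyond the scatter, for instance a longer chain, an amine or a carboxylic acid, or a benzyl ring bearing a fluoro or methoxy group of its own. They also leave open whether benzyl would behave the same way with methyl in place of the fluoro group, since only the fluoro-bearing pair compound 2 and compound 3 varies this chain.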